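A few compounds are considered here, and "the series" means these few. Any claim that something is new, unique, unknown or untested is made for them only; others in the source may bear on it.

Three compounds share one core and differ only in the group attached to it. Compound 1 `CCN(CC)C(=O)c1ccccc1OCC1=NCCN1` in a functional assay for activation of Alpha-1D adrenergic receptor (Homo sapiens), read by calcium flux (a higher number here means that more compound is needed for the effect, a lower number that less compound is needed), gives only a limit of the assay, < 5020 nM, and no number. Compound 2 `Cc1cccnc1-c1ccccc1OCC1=NCCN1` in this assay likewise gives only a limit, < 100000 nM. Among the compounds with values here, compound 3 `c1csc(-c2ccccc2OCC2=NCCN2)c1` is the one compound with an actual number: in this assay compound 3 gives 15.9 nM. Compound 4 `Cc1csc(-c2ccccc2OCC2=NCCN2)n1` differs from compound 3 in one place: 4-methyl-1,3-thiazol-2-yl in place of thiophen-2-yl on an aromatic carbon. No change of this kind has been measured among these compounds, so the step expected in this assay is a 2.5-fold higher number from compound 3 to compound 4 (0.40 log units; beyond the scatter), modest and toward needing somewhat more compound. The estimate for compound 4 in this assay is 40 nM, with a range from 8 nM to 200 nM.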

Compound 4, half-maximal effective concentration: < 100000 nM
Compound 4: no number, only a limit; the forecaster's own chance of this, stated with the estimate: 10%; the middle value lies beyond the limit too.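

In this assay, within the data shown here, compound 4 gives only a limit, < 100000 nM, so no step from compound 3 to compound 4 can be read. The compounds shown leave open how 4-methyl-1,3-thiazol-2-yl truly compares with thiophen-2-yl.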